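Series notes: from compound 2 to compound 4

A few compounds are considered here, and "the series" means these few. Any claim that something is new, unique, unknown or untested is made for them only; others in the source may bear on it.

Values in a functional assay on K562 cells (Homo sapiens) for antiproliferative activity, read by MTT assay, with a stated time of 48 h; a higher number here means a weaker inhibitor, a lower number a stronger inhibitor:
compound 1 `COC(=O)[C@H](CC(C)C)NC(=O)c1ccc(Oc2nc3ccccc3nc2C)cc1` gives 22600 nM
compound 2 `COC(=O)CNC(=O)c1ccc(Oc2nc3ccccc3nc2NC(C)(C)C)cc1` gives > 50000 nM
compound 3 `CCCCCCCCCCCCNc1nc2ccccc2nc1Oc1ccc(C(=O)N[C@H](C(=O)O)[C@H](C)CC)cc1` gives 21500 nM

Compound 2 gives > 50000 nM in this assay, and this is a limit of the assay, not a number. Its position in the series is therefore known only as a limit. Compound 1 gives 22600 nM and compound 3 gives 21500 nM, two values within the usual scatter of each other.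

The next compound to be measured is compound 4 `CC(C)C[C@H](NC(=O)c1ccc(Oc2nc3ccccc3nc2NC(C)(C)C)cc1)C(=O)O`. It carries 1-carboxy-3-methylbutyl in place of (methoxycarbonyl)methyl on an amide-type nitrogen of compound 2 (1-carboxy-3-methylbutyl in place of (methoxycarbonyl)methyl on an amide-type nitrogen). The rest of the structure is unchanged.

Going by the values given here, no measured pair differs in one place only, so no measured step guides this change. Among the compounds with values here, the expectation is weak and rests on the only two numbers available, from compound 1 at 22600 nM and compound 3 at 21500 nM. A modest step towards a stronger inhibitor is expected, and compound 4 may well be reported only as a limit too.

The estimate corresponds to an expected at least 1.2-fold lower number from compound 2 to compound 4 (0.09 log units; that floor lies within the scatter). For compound 4 the estimated value is 40000 nM, with an expected range of 18000 nM to 90000 nM.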

Compound 4, half-maximal inhibitory concentration: 42300 nM
For compound 4 the middle estimate is 1.1-fold (0.02 log units) below the measured one; measured number inside the range.
By their numbers in this assay, from the lowest: compounds 3, 1 and 4 (each within the scatter of the next). At a limit, above all of these: compound 2.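

In this assay, going by these compounds alone, 1-carboxy-3-methylbutyl in place of (methoxycarbonyl)methyl on the amide-type nitrogen gives the first step that can be read at a single place, with an at least 1.1-fold lower number from compound 2 to compound 4 (0.07 log units; that floor lies within the scatter). Within the data shown here, this change takes the shared core from a limit of the assay to a measured number, which no earlier compound could show for this position. Only a floor can be stated for the step, and it cannot be sized further, because compound 2 is reported as a limit and not as a number: the limit of > 50000 nM in this assay, at which 1 of the 4 values shown sits.

The compounds shown do not separate the change from ester to carboxylic acid from the growth of the chain, so a carboxymethyl group or a 1-(methoxycarbonyl)-3-methylbutyl group on the same nitrogen would be needed to tell these two parts apart. Also open, from the compounds shown here alone, is how this position responds to an amine-bearing chain, to a longer alkyl chain, or to the opposite configuration at the defined stereocentre of 1-carboxy-3-methylbutyl.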